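Working notes: 1H-indazol-4-yl to 1H-indazol-6-yl

The source may hold more compounds than are shown below. What is called first, only, known or untested is meant among the compounds shown, and "the series" means these compounds.

Measured in a functional assay on MCF7 cells (Homo sapiens) for cytotoxicity, read by CellTiter-Glo, with a stated time of 5 days; a higher number here means a weaker inhibitor, a lower number a stronger inhibitor:
- compound 1 `CC/C(=C(/c1ccc(/C=C/C(=O)O)cc1)c1ccc2[nH]c(=O)oc2c1)c1ccccc1`: 56 nM
- compound 2 `CC/C(=C(/c1ccc(/C=C/C(=O)O)cc1)c1cccc2[nH]ncc12)c1ccccc1`: 21 nM

Among the compounds with values here, of the two measured compounds, compound 2 has the lower number in this assay, at 21 nM, and compound 1 is its only comparison, at 56 nM.

Compound 3 `CC/C(=C(/c1ccc(/C=C/C(=O)O)cc1)c1ccc2cn[nH]c2c1)c1ccccc1` has not yet been measured. It has the same atoms as compound 2, joined differently: 1H-indazol-6-yl in place of 1H-indazol-4-yl on a double-bonded chain carbon bound to an aromatic carbon and a double-bonded chain carbon. In words, 1H-indazol-6-yl stands in place of 1H-indazol-4-yl on a double-bonded chain carbon bound to an aromatic carbon and a double-bonded chain carbon.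

Within the data shown here, only one measured step bears on this change: a 2.7-fold lower number from compound 1 to compound 2 (0.43 log units; beyond the scatter). It alters the group at that same place and is modest, though beyond the scatter. Among the measured compounds shown here, no measured step compares two indazolyl groups, so the direction rests on little. With compound 2 at the low end of a very small set, a modest move toward a higher number is expected rather than a further fall. The expected change is a 1.9-fold higher number from compound 2 to compound 3 (0.28 log units; within the scatter), which is an estimate with wide uncertainty. The estimated value for compound 3 is 40 nM, with an expected range of 13 nM to 120 nM.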

Compound 3, half-maximal inhibitory concentration: 570 nM
Estimate against measurement, compound 3: 14-fold (1.15 log units) below, and the stated range ends below it.
By their numbers in this assay, from the lowest: compound 2; then compound 1; then compound 3.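

In this assay, the attachment point of the indazolyl group alone has a large effect: with the same atoms joined differently, 1H-indazol-6-yl in place of 1H-indazol-4-yl gives a 27-fold higher number from compound 2 to compound 3 (1.43 log units; beyond the scatter). The group of compound 1 also compares differently with the two indazolyl groups, since a 2.7-fold lower number from compound 1 to compound 2 (0.43 log units; beyond the scatter) is followed by the opposite direction in a 10-fold higher number from compound 1 to compound 3 (1.01 log units; beyond the scatter), so at this place, on a double-bonded chain carbon bound to an aromatic carbon and a double-bonded chain carbon, the outcome depends on how the indazolyl group is joined and not merely on its presence. No measurement in hand accounts for the difference between the two indazolyl groups.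

The compounds shown leave open where a 1H-indazol-5-yl group would fall relative to compound 2 and compound 3, and whether a 1-methyl-1H-indazol-4-yl group would stay close to compound 2. They also leave open whether the gap between the two indazolyl groups would persist with a primary amide in place of the carboxylic acid of the shared core.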